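Methylamino in place of hydrogen on the shared core

The source may hold more compounds than are shown below. What is called first, only, known or untested is meant among the compounds shown, and "the series" means these compounds.

Of the compounds shown here, three built on one shared core have been tested in a functional assay on NCI-H460 cells (Homo sapiens) for cytotoxicity, read by MTT assay, with a stated time of 72 h; on this read-out lower numbers stand for stronger inhibition and higher numbers for weaker inhibition. Compound 3 `O=C(Nc1ccc(-n2ncc3ccccc32)cc1)Nc1ccc(Cl)c(C(F)(F)F)c1` carries only hydrogen at the site of interest and gives 5500 nM, the highest of the three numbers. Compound 1 `O=C(Nc1ccc(-n2ncc3c(Br)cccc32)cc1)Nc1ccc(Cl)c(C(F)(F)F)c1` bears bromo at that site and gives 1300 nM, while compound 2 `Cc1cccc2c1cnn2-c1ccc(NC(=O)Nc2ccc(Cl)c(C(F)(F)F)c2)cc1` bears methyl and gives 2500 nM. Going by the values given here, two measured steps bear directly on this site: a 4.2-fold higher number from compound 1 to compound 3 (0.63 log units; beyond the scatter) and a 2.2-fold higher number from compound 2 to compound 3 (0.34 log units; beyond the scatter), both modest and beyond the scatter, whereas a 1.9-fold higher number from compound 1 to compound 2 (0.28 log units; within the scatter) lies within it. Replacing hydrogen by either group thus lowered the number to a modest degree.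

Compound 4 `CNc1cccc2c1cnn2-c1ccc(NC(=O)Nc2ccc(Cl)c(C(F)(F)F)c2)cc1` differs from compound 3 by methylamino in place of hydrogen on an aromatic carbon. Methylamino is neither bromo nor methyl, and no measured compound carries a donor or acceptor group at this site, so the direction can only be inferred from the two groups already tested. Since both lowered the number, a modest decrease in this assay is expected, though with wide uncertainty. Compound 4 is therefore estimated at 3000 nM, with a range from 1200 nM to 8000 nM. The expected step of a 1.8-fold lower number from compound 3 to compound 4 (0.26 log units; within the scatter) is of roughly the size seen for methyl.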

Compound 4, half-maximal inhibitory concentration: 2600 nM
Compound 4: the middle estimate sits 1.2-fold (0.06 log units) above what was measured; the range from low to high includes it.
By their numbers in this assay, from the lowest: compounds 1, 2 and 4 (each within the scatter of the next); then compound 3.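

In this assay the step of a 2.1-fold lower number from compound 3 to compound 4 (0.33 log units; beyond the scatter) shows that methylamino on this aromatic carbon, a group with a nitrogen and with one hydrogen-bond donor and one acceptor, also gives a modest decrease beyond the scatter, so all three groups tested at the site lower the number relative to hydrogen, and none of compounds 1, 2 and 4 goes against this. The step of a 1.0-fold higher number from compound 2 to compound 4 (0.02 log units; within the scatter) and the step of a 2.0-fold higher number from compound 1 to compound 4 (0.30 log units; within the scatter) both lie within the scatter, so this assay does not separate methylamino from methyl or from bromo, and the site has so far tolerated all three groups with no measurable difference among them. No measured evidence accounts for this shared decrease or says what the three groups have in common at this site.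

As far as these compounds go, whether an unsubstituted amine, a dimethylamino group, a carboxylic acid or a longer chain on the same aromatic carbon would stay in this range or move beyond it remains open. Also open, from the compounds shown here alone, is whether the modest decrease seen with methylamino would carry over to any other cell line or read-out.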